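Antiproliferative series: octyl replaced by hydroxy on the core

The compounds below may be only part of what the source reports. "The series", "measured", "known", "first", "only" and "open" are said of these compounds alone.

Measured compounds
Compound 1 `CCCCCCCCc1ccc(CCC(CO)(CO)NC(C)=O)c2ccccc12` — 36500 nM
Compound 2 `CCCCCCCCc1ccc(CCC(CO)(CO)NC(=O)CCCCC)c2ccccc12` — 20300 nM

In a functional assay on HT-29 cells (Homo sapiens) for antiproliferative activity, read by sulforhodamine B assay, with a stated time of 72 h (a higher number here means a weaker inhibitor, a lower number a stronger inhibitor), compound 1 gives 36500 nM. Compound 2 gives 20300 nM in this assay. Going by the values given here, the single measured step, a 1.8-fold lower number from compound 1 to compound 2 (0.25 log units; within the scatter), alters only the acyl part of the head group and leaves the octyl-bearing ring untouched. Compound 1 holds the highest of the two numbers, with compound 2 nearest.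

Compound 3 `CC(=O)NC(CO)(CO)CCc1ccc(O)c2ccccc12` has not yet been run in this assay. It differs from compound 1 in one place: hydroxy in place of octyl on an aromatic carbon. Among the compounds with values here, no measured step touches this aromatic carbon or the octyl group on it, so the step of a 1.8-fold lower number from compound 1 to compound 2 (0.25 log units; within the scatter) offers no guide to the size or direction of the move. The estimate therefore carries a wide range and rests only on the structures themselves. The number for compound 3 is expected to come out higher than that of compound 1, a step of a 2.5-fold higher number from compound 1 to compound 3 (0.39 log units; beyond the scatter), with a fair chance that this assay reports only a limit. The estimate for compound 3 is 90000 nM, in the range 30000 nM to 300000 nM.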

Compound 3, half-maximal inhibitory concentration: > 80000 nM
Compound 3 was reported as a limit; the forecaster's own chance of this, stated with the estimate: 40%; the middle value lies beyond the limit too.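

In this assay compound 3 gives > 80000 nM, which is a limit of the assay and not a number. Hydroxy in place of octyl on this aromatic carbon, para to a large group, gives an at least 2.1-fold higher number from compound 1 to compound 3 (0.34 log units; beyond the scatter). Going by these compounds alone, this is the first sign that this position matters to the read-out, as the only earlier step, a 1.8-fold lower number from compound 1 to compound 2 (0.25 log units; within the scatter), lay in the acyl part of the head group and stayed within the scatter. The direction of the new step and its minimum size are fixed, but its full size stays unread: the limit of > 80000 nM in this assay, at which 1 of the 3 values shown sits.

The single change removes octyl and brings in hydroxy together, and the compounds shown do not separate the loss of the chain from the arrival of the hydroxy group. Also open, going by these compounds, is how a butyl chain, a longer chain, a methoxy group or an amine on this aromatic carbon would read in this assay, and whether the longer acyl group of compound 2 would make any difference alongside hydroxy on the core.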